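Working notes: from compound 1 to compound 4

The source may hold more compounds than are shown below. What is called first, only, known or untested is meant among the compounds shown, and "the series" means these compounds.

Measured in a functional assay on K562 cells (Homo sapiens) for cytotoxicity, read by ELISA, with a stated time of 4 days; on this read-out higher numbers stand for weaker inhibition and lower numbers for stronger inhibition:
- compound 1 `Cc1ccsc1-c1cc(-c2ccc(Cl)o2)cc(-c2cccc(Cl)c2)n1`: 13400 nM
- compound 2 `Cc1ccsc1-c1cc(-c2ccc(Cl)o2)cc(-c2ccc(Cl)cc2)n1`: 15600 nM
- compound 3 `Cc1ccsc1-c1cc(-c2ccc(Cl)o2)cc(-c2cccnc2)n1`: 12300 nM

Compound 1 has no distinct rank, as all three values lie within the scatter of each other. The next compound to be measured is compound 4 `Clc1cccc(-c2cc(-c3ccc(Cl)o3)cc(-c3ccc(Cl)s3)n2)c1`, which carries 5-chlorothiophen-2-yl in place of 3-methylthiophen-2-yl on an aromatic carbon.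

Within the data shown here, no measured step covers this change. The nearest evidence comes from exchanges of the 3-chlorophenyl group elsewhere on the shared core, which give a 1.2-fold higher number from compound 1 to compound 2 (0.07 log units; within the scatter), a 1.1-fold lower number from compound 1 to compound 3 (0.04 log units; within the scatter) and a 1.3-fold lower number from compound 2 to compound 3 (0.10 log units; within the scatter). All three steps are small, but none alters the 3-methylthiophen-2-yl group, so they bear on the change only indirectly. No step beyond the scatter is expected in this assay, and the data suggest no direction.

The expected step is a 1.1-fold lower number from compound 1 to compound 4 (0.05 log units; within the scatter). The range is kept wide, as this group has not been varied in any measured compound. For compound 4 the estimated value is 12000 nM, with an expected range from 4000 nM to 35000 nM.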

Compound 4, half-maximal inhibitory concentration: 19600 nM
Estimate against measurement, compound 4: 1.6-fold (0.21 log units) below; the measured number falls inside the stated range.
By their numbers in this assay, from the lowest: compounds 3, 1, 2 and 4 (each within the scatter of the next).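

In this assay, compound 4 shows that the position next to the ring nitrogen can also be varied: 5-chlorothiophen-2-yl in place of 3-methylthiophen-2-yl gives a 1.5-fold higher number from compound 1 to compound 4 (0.17 log units; within the scatter). Among these compounds, the earlier compounds changed only the 3-chlorophenyl group, so this is the first reading at this position, and it shows that moving the substitution on the thiophene and exchanging methyl for chlorine leaves the number within the scatter. No measurement on hand explains this result.

Going by these compounds, with only these two thiophene groups at this position, it remains open whether the position would respond to a different kind of group, such as an amine or a carboxylic acid. The 5-chlorofuran-2-yl group is the same in all the compounds shown, so its contribution also remains open.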